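A Bromomethyl Amide Variant of Compound 1

The compounds below may be only part of what the source reports. "The series", "measured", "known", "first", "only" and "open" are said of these compounds alone.

Compound 1 `CCC/C=C/C(=O)N(Cc1ccc(OC)c(O)c1)c1cc(OC)c(OC)c(OC)c1` has the lower of the two numbers recorded so far in a functional assay on HCT-116 cells (Homo sapiens) for inhibition, read by MTT assay, with a stated time of 48 h; a lower number here means a stronger inhibitor, a higher number a weaker inhibitor: compound 1 gives 95 nM. Compound 2 `C/C=C/C(=O)N(Cc1ccc(OC)cc1)c1cc(OC)c(OC)c(OC)c1` stands well apart from it, since in this assay compound 2 gives 500 nM, a gap beyond the usual scatter. Among the compounds with values here, no step between measured compounds that differ in one place is available, so the comparison of compound 1 and compound 2 rests on these two values alone.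

Compound 3 `COc1ccc(CN(C(=O)CBr)c2cc(OC)c(OC)c(OC)c2)cc1O` keeps the core of compound 1 and differs from it in one place: bromomethyl in place of pent-1-en-1-yl on a carbonyl carbon. Within the data shown here, no pair of measured compounds here shows how such a change on the carbonyl carbon plays out. The step from compound 1 to compound 3 is expected to be a modest loss, a 2.1-fold higher number from compound 1 to compound 3 (0.32 log units; beyond the scatter), a size near the edge of the scatter. Among the measured compounds shown here, compound 3 is estimated at 200 nM, within a range from 50 nM to 1000 nM; no measured step bears on this change, so the span is wide.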

Compound 3, half-maximal inhibitory concentration: 68 nM
Estimate against measurement, compound 3: 2.9-fold (0.47 log units) above; the measured number falls inside the stated range.
By their numbers in this assay, from the lowest: compounds 3 and 1 (each within the scatter of the next); then compound 2.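

In this assay, the change from pent-1-en-1-yl to bromomethyl on a carbonyl carbon reads as a 1.4-fold lower number from compound 1 to compound 3 (0.15 log units; within the scatter). Within the data shown here, this is the first measured step at this position, and it shows that a chain of 5 heavy atoms with 1 double bond can give way to a group of 2 heavy atoms, one of them bromine, with no difference beyond the scatter. No measurement at hand says why the two compounds read alike.

The compounds shown leave open how other groups on this carbonyl carbon would read, such as a plain methyl, a chloromethyl or an amine. They also leave open whether bromomethyl in place of pent-1-en-1-yl would read the same way if the rest of the core of compound 1 were different.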